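The compounds below may be only part of what the source reports. "The series", "measured", "known", "first", "only" and "open" are said of these compounds alone.

Measured compounds:
compound 1 `NC(=O)/C=C1\CCc2c(F)cc(F)cc21` — 138 mg/kg
compound 2 `NC(=O)/C=C1\CCc2cc(F)ccc21` — > 100 mg/kg
compound 3 `NC(=O)/C=C1\CCc2ccc(F)cc21` — 90 mg/kg

All three carry the same acrylamide-bearing bicyclic core and differ only in the fluorines on the aromatic ring. In a functional assay on the whole organism with Mus musculus as the target, in the rotarod test (on this read-out higher numbers stand for an effect only at larger amounts of compound and lower numbers for an effect already at smaller amounts), compound 3 gives 90 mg/kg and compound 1 gives 138 mg/kg. For compound 2 the entry > 100 mg/kg is a limit of the assay and not a number; it sits at the limit of > 100 mg/kg in this assay, at which 1 of the 3 values shown sits.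

For the measured compounds named here, the one step counted between measured compounds is fluoro in place of hydrogen on an aromatic carbon, which gives a 1.5-fold higher number from compound 3 to compound 1 (0.19 log units; within the scatter) in this assay. Compounds 2 and 3 hold the same atoms joined differently; the difference between the two cores is not broken down here.

Compound 4 `NC(=O)/C=C1\CCc2c1ccc(F)c2F` is not yet measured. It arises from compound 2 by fluoro in place of hydrogen on an aromatic carbon. This is the same kind of change as that from compound 3 to compound 1, but the surroundings differ: here the entering fluoro is ortho to a fluoro group, whereas from compound 3 to compound 1 it was meta to a fluoro group. For compound 4 in this assay a step that the limit leaves unreadable from compound 2 to compound 4 is expected, resting on the small step from compound 3 to compound 1 a 1.5-fold higher number from compound 3 to compound 1 (0.19 log units; within the scatter) and on the fact that compound 2 is known only as a limit. Compound 4 is therefore estimated at 130 mg/kg, spanning 60 mg/kg to 280 mg/kg, with a fair chance that only a limit is recorded.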

Compound 4, dose for half-maximal effect: 50 mg/kg
Compound 4: the middle estimate sits 2.6-fold (0.41 log units) above what was measured; measured number outside the range, below it.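

Fluoro in place of hydrogen on an aromatic carbon gives an at least 2.0-fold lower number from compound 2 to compound 4 (0.30 log units; that floor lies within the scatter), and set beside a 1.5-fold higher number from compound 3 to compound 1 (0.19 log units; within the scatter), the same change does not carry over with the same outcome from one core to the other: the same change on two cores in this assay, a 1.5-fold higher number (0.19 log units; within the scatter) from compound 3 to compound 1 and an at least 2.0-fold lower number (0.30 log units; that floor lies within the scatter) from compound 2 to compound 4, at least 3.0-fold (0.48 log units) apart, beyond the scatter of two such steps

This comparison rests on a single pair per core, and the surroundings of the entering fluoro also differ, ortho to a fluoro group in one pair and meta to a fluoro group in the other, so it does not show whether the core or the place of the fluoro goes with the gap. Compound 2 is recorded at > 100 mg/kg, a limit of the assay and not a number, so the new step is only a floor and its full size cannot be read.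

Still open, on these data alone, is how a chloro or a methoxy group in the place of the entering fluoro would read in this assay, which would test whether the result belongs to fluoro in particular. Also open, as far as these compounds go, is whether the result holds with a methyl group on the amide nitrogen or with a carboxylic acid in place of the amide.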